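A Swap on the Amide Nitrogen at the Assay Limit

This account rests on a few compounds, and the source may have more. Where it says the series, first, only, none or still open, it means among the compounds named here.

Compound 1 `C#CCCOC(=O)c1ccc(C(CC)(CC)c2ccc(OCCC(O)(CC)CC)c(C)c2)n1CC`: > 50000 nM, a limit
Compound 2 `CCOc1ccc(NC(=O)c2ccc(C(CC)(CC)c3ccc(OCCC(O)(CC)CC)c(C)c3)n2CC)cc1`: > 50000 nM, a limit

Both readings come from an ADME assay on L02 cells (Homo sapiens) for antiproliferative activity, read by MTT assay, with a stated time of 48 h; on this read-out higher numbers stand for weaker inhibition and lower numbers for stronger inhibition. Neither is a true number, so compound 2 stands only at a limit and not at a measured potency. For the measured compounds named here, the one measured step is a step that the two limits leave unreadable from compound 1 to compound 2, and it gives no size to carry forward. That step changed the group on the same carbonyl carbon, and both compounds remain at the limit of > 50000 nM in this assay, at which 2 of the 2 values shown sit.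

Compound 3 `CCC(C)C(NC(=O)c1ccc(C(CC)(CC)c2ccc(OCCC(O)(CC)CC)c(C)c2)n1CC)C(=O)OC` carries a group of 9 heavy atoms (7 carbon, 2 oxygen; no ring) in place of a group of 9 heavy atoms (8 carbon, 1 oxygen; one six-membered aromatic ring of carbon only), on an amide-type nitrogen. The six-membered aromatic ring leaves, and no ring enters.

Going by the values given here, the only guide is therefore (the limit of > 50000 nM in this assay, at which 2 of the 2 values shown sit), which shows no measurable inhibition from either compound at the tested concentrations. With no readable step to suggest a direction, nothing beyond the usual scatter is expected in this assay. The expected change is a number no higher from compound 2 to compound 3 (the limit leaves the size open). A report of another limit is the most likely outcome. For compound 3 the estimate is 50000 nM, with an expected range of 25000 nM to 100000 nM.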

Compound 3, half-maximal inhibitory concentration: > 50000 nM
Compound 3 was reported as a limit; the forecaster's own chance of this, stated with the estimate: 85%; the middle value sits exactly at the limit.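

Compound 3 gives > 50000 nM in this assay and this is a limit, not a number. For the compounds shown here, no step among compound 1, compound 2 and compound 3 can be read, as all three stand at a limit: the limit of > 50000 nM in this assay, at which 3 of the 3 values shown sit. These compounds leave open whether any other group on the carbonyl carbon would give a true number in this assay at all.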